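Moving from 4-methoxyphenyl to 3-methoxyphenyl: working notes

The source may report more compounds than this note shows. Statements on the series, on what has been measured and on what is new or still open speak of the compounds shown alone.

In an ADME assay on L02 cells (Homo sapiens) for inhibition, read by CCK-8 assay, with a stated time of 48 h (on this read-out lower numbers stand for stronger inhibition of growth and higher numbers for weaker inhibition of growth), compound 3 (`COc1ccc(Nc2nc(Nc3ccc(N4CCN(C)CC4)cn3)ncc2Cl)cc1`) gives 3150 nM and holds the lower of the two numbers available. The other number belongs to compound 1 (`COc1ccc(CNc2nc(Nc3ccc(N4CCN(C)CC4)cn3)ncc2Cl)cc1`), which gives 12900 nM in this assay and is the nearest measured neighbour of compound 3. In this assay compound 2 (`CC(C)c1ccccc1Nc1nc(Nc2ccc(N3CCN(C)CC3)cn2)ncc1Cl`) stands as "not determined" (no result reported), with no result reported.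

Compound 4 (`COc1cccc(Nc2nc(Nc3ccc(N4CCN(C)CC4)cn3)ncc2Cl)c1`) has 3-methoxyphenyl in place of 4-methoxyphenyl on a nitrogen on an aromatic ring, so the two compounds have the same atoms, joined differently. Going by the values given here, the only measured step is modest: a 4.1-fold lower number from compound 1 to compound 3 (0.61 log units; beyond the scatter) and it exchanges 4-methoxybenzyl for 4-methoxyphenyl at that same place. Among the compounds with values here, this step bears on the change only indirectly, as no measured pair moves the methoxy group. No shift beyond the scatter is therefore expected, and no direction is favoured. The expected step is small: a 1.2-fold higher number from compound 3 to compound 4 (0.08 log units; within the scatter) and this remains an estimate. Compound 4 is expected to give 3800 nM (estimated range 1700 nM to 8500 nM).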

Compound 4, concentration for 50% growth inhibition: 3470 nM
For compound 4 the middle estimate is 1.1-fold (0.04 log units) above the measured one; measured number inside the range.
By their numbers in this assay, from the lowest: compounds 3 and 4 (each within the scatter of the next); then compound 1.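

In this assay, going by these compounds alone, 3-methoxyphenyl in place of 4-methoxyphenyl gives a 1.1-fold higher number from compound 3 to compound 4 (0.04 log units; within the scatter), the first measured pair in which only the methoxy group moves, and the two compounds cannot be told apart on this read-out. The step of a 3.7-fold lower number from compound 1 to compound 4 (0.57 log units; beyond the scatter) shows that the exchange from 4-methoxybenzyl remains beyond the scatter with 3-methoxyphenyl as well as with 4-methoxyphenyl, so among these three compounds the separation follows the loss of the benzyl form and not the methoxy placement. No measurement at hand gives a reason for either step.

From the compounds shown here alone, it remains open whether an amine or a carboxylic acid in place of the methoxy group would give a step beyond the scatter. Compound 2 has no reported result, so it adds nothing on other groups at this place.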